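The source may report more compounds than this note shows. Statements on the series, on what has been measured and on what is new or still open speak of the compounds shown alone.

Measured so far:
compound 1, `O=C(O)Cc1sc(C(c2ccccc2)c2ccccc2)nc1-c1ccccc1`: 570 nM
compound 2, `O=C(O)Cc1sc(C(c2ccc(F)cc2)c2ccc(F)cc2)nc1-c1ccnc(N2CCC2)c1`: 660 nM

Both numbers come from an in vitro assay on HEK385-7 cells for displacement of a labelled ligand from prostaglandin D2 receptor 2 (Homo sapiens); on this read-out lower numbers stand for stronger inhibition and higher numbers for weaker inhibition. Compound 2 and compound 1 lie within the usual scatter of each other; nothing separates them. Compound 3, `O=C(O)Cc1sc(C(c2ccc(F)cc2)c2ccc(F)cc2)nc1-c1ccoc1`, awaits measurement in this assay. Its change from compound 2: furan-3-yl in place of 2-(azetidin-1-yl)pyridin-4-yl on an aromatic carbon. For the measured compounds named here, no measured pair isolates this change; compound 1 and compound 2 already differ at this aromatic carbon, among other places, and still agree within the scatter. Compound 3 is therefore expected to give 700 nM, with a range of 250 nM to 2000 nM. The expected step of a 1.1-fold higher number from compound 2 to compound 3 (0.03 log units; within the scatter) is none beyond the scatter.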

Compound 3, half-maximal inhibitory concentration: 14 nM
Beside the measured number, compound 3's estimate is 50-fold (1.70 log units) above it; measured number below the stated range.
By their numbers in this assay, from the lowest: compound 3; then compounds 1 and 2 (each within the scatter of the next).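

In this assay, the group on the aromatic carbon next to the ring nitrogen strongly affects the read-out: furan-3-yl in place of 2-(azetidin-1-yl)pyridin-4-yl gives a 47-fold lower number from compound 2 to compound 3 (1.67 log units; beyond the scatter). This single change both removes the four-membered non-aromatic ring and replaces the six-membered aromatic ring with a five-membered one, so the step cannot be assigned to either part. Nothing available explains the step. Also open, from the compounds shown here alone, is whether a plain pyridin-4-yl or a thiophen-3-yl on this carbon would stay close to compound 3 or to compound 2.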